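A few compounds are considered here, and "the series" means these few. Any claim that something is new, unique, unknown or untested is made for them only; others in the source may bear on it.

Compound 1 `CC(C)n1c(=O)n(C(=O)NCCN2CCNCC2)c2ccccc21`: > 100%
Compound 2 `CCCCCN1CCC(NC(=O)c2cc(Cl)c(N)cc2OC)CC1`: > 100%

Both were tested in a functional assay on HEK293 cells for activation of 5-hydroxytryptamine receptor 4 (Homo sapiens), read by cAMP accumulation; on this read-out higher numbers stand for larger maximal responses and lower numbers for smaller maximal responses. For compound 1 the value > 100% is a limit of the assay, not a measured number. For compound 2 the value > 100% is likewise a limit, not a number. Compound 2 thus stands at the upper edge of what this assay reports, and it does not stand there alone: the limit of > 100% in this assay, at which 2 of the 2 values shown sit. Among the compounds with values here, no two measured compounds differ in a single place, so no measured step shows how a small change in structure moves the read-out.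

Compound 3 `COc1cc(N)c(Cl)cc1C(=O)NC1CCN(CCCCCN2CCCCC2)CC1` has not yet been measured. It differs from compound 2 in one place: piperidin-1-yl in place of hydrogen on a saturated chain carbon, five bonds along the chain from an amine nitrogen in a ring. The rest of the shared core is kept. Within the data shown here, with no measured step to build on, the expectation rests on the limit reached by compound 2; a step from compound 2 to compound 3 of no more than the usual scatter is expected in this assay, in either direction. Compound 3 is expected to give 100%, most likely between 85% and 115%. That estimate means a step of a number no higher from compound 2 to compound 3 (the limit leaves the size open), which is expected to stay within the scatter.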

Compound 3, intrinsic activity: the largest response reached, in percent of the reference agonist's: > 100%
Compound 3: no number, only a limit (the forecaster's own chance of this, stated with the estimate: 60%); the middle value lies on the limit itself.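

In this assay compound 3 gives > 100%, which is a limit and not a number. Compound 2 also sits at a limit, so the change from compound 2 to compound 3 cannot be read: the limit of > 100% in this assay, at which 3 of the 3 values shown sit.

The compounds shown leave open how large each maximal response really is, and whether piperidin-1-yl in place of hydrogen changes it at all.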